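The source may hold more compounds than are shown below. What is called first, only, known or untested is meant among the compounds shown, and "the series" means these compounds.

Measured compounds:
compound 1 `CC#CC(CC(=O)O)c1ccc(OCc2ccc(C(=O)N3CCN(c4ccccc4)CC3)s2)cc1` — 72 nM
compound 2 `CC#CC(CC(=O)O)c1ccc(OCc2ccc(C(=O)N3CCN(c4ccc(C(C)(C)C)cc4)CC3)s2)cc1` — 417 nM

Within the data shown here, in a functional assay on HEK293 cells for agonist activity at Free fatty acid receptor 1 (Homo sapiens), read by fluorescence and calcium flux (on this read-out lower numbers stand for an effect already at smaller amounts and higher numbers for an effect only at larger amounts of compound), compound 2 gives 417 nM, the higher of the two numbers measured so far; its nearest neighbour is compound 1, which in this assay gives 72 nM. Among the measured compounds shown here, the one measured step, a 5.8-fold higher number from compound 1 to compound 2 (0.76 log units; beyond the scatter), shows that placing a tert-butyl on the aromatic carbon of the phenyl group raised the number clearly beyond the scatter.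

Compound 3 `CC#CC(CC(=O)O)c1ccc(OCc2ccc(C(=O)N3CCN(c4ccc(OC)cc4)CC3)s2)cc1` is not yet measured. It differs from compound 2 by methoxy in place of tert-butyl on an aromatic carbon. For the measured compounds named here, the measured step bears on this only indirectly: it tells how hydrogen and tert-butyl compare at this carbon, but no compound with a methoxy at this place has been measured, so the data give no direct reading of methoxy.

Taking compound 1 and compound 2 as the two ends of what is known at this carbon, compound 3 is expected to fall between them, with an expected step of a 2.8-fold lower number from compound 2 to compound 3 (0.44 log units; beyond the scatter) from compound 2. The estimate for compound 3 in this assay is 150 nM, in a range from 60 nM to 400 nM.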

Compound 3, half-maximal effective concentration: 289 nM
Compound 3: middle estimate off by 1.9-fold (0.28 log units), on the low side; the measured number falls inside the stated range.
By their numbers in this assay, from the lowest: compound 1; then compounds 3 and 2 (each within the scatter of the next).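

Set against the earlier pair, compound 3 shows that the number at this aromatic carbon, para to a large group, does not simply follow the size of the group: in this assay the step of a 1.4-fold lower number from compound 2 to compound 3 (0.16 log units; within the scatter) cannot separate methoxy, with two heavy atoms including one oxygen, from tert-butyl, with four carbons. Hydrogen remains apart from both groups, as the step of a 4.0-fold higher number from compound 1 to compound 3 (0.60 log units; beyond the scatter) joins the earlier step of a 5.8-fold higher number from compound 1 to compound 2 (0.76 log units; beyond the scatter) beyond the scatter, so among these three compounds both groups tried on this carbon give a higher number than hydrogen, and no compound here goes against that. No measurement offered here explains why methoxy and tert-butyl read alike or why either differs from hydrogen.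

As far as these compounds go, whether a hydroxyl, a chlorine or an amine on this carbon would stand nearer to compound 1 or with the two larger groups remains open. So does whether a methoxy on another carbon of this six-membered ring would give a number like that of compound 3.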